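Macrophage cytotoxicity: from compound 3 to compound 4

The source may report more compounds than this note shows. Statements on the series, on what has been measured and on what is new or still open speak of the compounds shown alone.

Measured compounds:
compound 1 `Nc1ncnc2c([C@@H]3O[C@H](CO)[C@@H](O)[C@H]3O)cn(-c3ccc(Br)cc3)c12` — in an ADME assay on cells (Macrophage, Mus musculus) for cytotoxicity (on this read-out higher numbers stand for lower toxicity in this test and lower numbers for higher toxicity in this test), compound 1 gives > 64000 nM, a limit of the assay.
compound 2 `OC[C@H]1O[C@@H](c2cnn3c(O)ncnc23)[C@H](O)[C@@H]1O` — in this assay compound 2 gives > 64000 nM, a limit of the assay.
compound 3 `O=c1[nH]cnn2c([C@@H]3O[C@H](CO)[C@@H](O)[C@H]3O)ccc12` — in this assay compound 3 gives > 64000 nM, a limit of the assay.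

Compound 3 therefore stands where the other two stand: no number is known for it, only the limit, and all three values sit at that same point (the limit of > 64000 nM in this assay, at which 3 of the 3 values shown sit). Going by the values given here, no step between measured compounds can be computed, so the series gives no size for any change in this read-out.

Compound 4 `O=c1[nH]cnn2c([C@@H]3O[C@H](CO)C[C@H]3O)ccc12` is the next compound, not yet measured. It differs from compound 3 in one place: hydrogen in place of hydroxy on a saturated ring carbon. The group that leaves is a hydroxy on a saturated ring carbon of the five-membered non-aromatic ring with one oxygen; a hydrogen enters in its stead.

With every shown value at the limit (the limit of > 64000 nM in this assay, at which 3 of the 3 values shown sit), no step beyond the scatter is expected from compound 3 to compound 4, and the step is estimated as a step that the limit leaves unreadable from compound 3 to compound 4. Compound 4 is expected to give about 80000 nM in this assay, in the range 30000 nM to 250000 nM, most likely again as a limit rather than a number.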

Compound 4, half-maximal cytotoxic concentration: > 64000 nM
Compound 4: only a limit was reported; the forecaster's own chance of this, stated with the estimate: 80%; the middle value does not contradict the limit.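

No size can be read for the exchange of hydroxy for hydrogen on a saturated ring carbon between compound 3 and compound 4 in this assay, because both values are limits of the assay: the limit of > 64000 nM in this assay, at which 4 of the 4 values shown sit.

The compounds shown leave open whether this exchange shifts the read-out at all, and at what concentration any of them would give an actual number in this assay.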